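Replacing the 4-methylpiperazin-1-yl group on a carbonyl carbon

The compounds below may be only part of what the source reports. "The series", "measured", "known", "first", "only" and "open" are said of these compounds alone.

In a functional assay on EBC-1 cells (Homo sapiens) for antiproliferative activity, with a stated time of 72 h (a lower number here means a stronger inhibitor, a higher number a weaker inhibitor), three compounds built on a shared core have been measured. Compound 1 `N#Cc1ccc(-c2cc(F)c3ncc(Cc4ccc5ncccc5c4)n3c2)cc1F`, which carries cyano, gives 145 nM. Compound 2 `COc1ccc(-c2cc(F)c3ncc(Cc4ccc5ncccc5c4)n3c2)cc1F`, with methoxy in place of cyano, gives 407 nM. Compound 3 `CN1CCN(C(=O)c2ccc(-c3cc(F)c4ncc(Cc5ccc6ncccc6c5)n4c3)cc2F)CC1`, with (4-methylpiperazin-1-yl)carbonyl in place of cyano, gives 869 nM, the highest number of the three and therefore the weakest inhibitor among them.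

Compound 4 `CN(C)CCNC(=O)c1ccc(-c2cc(F)c3ncc(Cc4ccc5ncccc5c4)n3c2)cc1F` keeps the carbonyl but has (2-(dimethylamino)ethyl)amino in place of 4-methylpiperazin-1-yl on a carbonyl carbon. Going by the values given here, no measured step exchanges one group on this carbonyl for another, so the evidence is indirect. The nearest steps are those that introduce the (4-methylpiperazin-1-yl)carbonyl: a 6.0-fold higher number from compound 1 to compound 3 (0.78 log units; beyond the scatter), and a 2.1-fold higher number from compound 2 to compound 3 (0.33 log units; beyond the scatter). The remaining step is a 2.8-fold higher number from compound 1 to compound 2 (0.45 log units; beyond the scatter). All three are modest, and each replaces the whole group on an aromatic carbon, whereas the change to compound 4 leaves the carbonyl in place. The data do not favour either direction, so no step beyond the scatter is expected. The expected change is a 1.1-fold lower number from compound 3 to compound 4 (0.05 log units; within the scatter). For compound 4, the estimated value is 780 nM, with an expected range from 330 nM to 1800 nM.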

Compound 4, half-maximal inhibitory concentration: 49 nM
Compound 4: middle estimate off by 16-fold (1.20 log units), on the high side; measured number outside the range, below it.
By their numbers in this assay, from the lowest: compound 4; then compound 1; then compound 2; then compound 3.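

In this assay, going by these compounds alone, the part of the group beyond the carbonyl proves to matter at this position: the earlier steps each replaced a whole group on an aromatic carbon, whereas an 18-fold lower number from compound 3 to compound 4 (1.25 log units; beyond the scatter) leaves the carbonyl in place and is the largest step in the set. The carbonyl-linked group therefore does not weaken the compounds in itself, since compound 4 also moves past both earlier comparators, with an 8.3-fold lower number from compound 2 to compound 4 (0.92 log units; beyond the scatter) and a 3.0-fold lower number from compound 1 to compound 4 (0.47 log units; beyond the scatter) in the same direction, reversing the position of compound 3 at the weak end. This single exchange removes the ring of 4-methylpiperazin-1-yl and adds the hydrogen-bond donor of (2-(dimethylamino)ethyl)amino, and the compounds shown do not separate those two differences.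

No measurement offered here accounts for the size of this step. Still open, on these data alone, is how the same carbonyl would fare carrying (3-(dimethylamino)propyl)amino as a longer chain, (2-(dimethylamino)ethyl)(methyl)amino with the amide hydrogen replaced by methyl, or a ring such as morpholin-4-yl.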